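Cyanomethyl pyrazole series: acetyl for dimethylamino on outer ring

A few compounds are considered here, and "the series" means these few. Any claim that something is new, unique, unknown or untested is made for them only; others in the source may bear on it.

Measured compounds:
compound 1 `COc1cc(C)cc(-c2c(-c3ccnc(-c4ccc(N(C)C)cc4)c3)cnn2CC#N)c1`: -43%
compound 2 `Cc1cc(O)cc(-c2nn(CC#N)cc2-c2ccnc(-c3ccc(Oc4ccccc4)cc3)c2)c1`: 89%
compound 3 `COc1cc(C)cc(-c2nn(CC#N)cc2-c2ccc(-c3cccc(C(C)=O)c3)nc2)c1`: 11%

In a functional assay on MDA-MB-435 cells (Homo sapiens) for cytotoxicity, read by sulforhodamine B assay, with a stated time of 48 h, tested at 100 nM (on this read-out lower numbers stand for a stronger effect and higher numbers for a weaker effect at the one concentration tested), compound 1 gives -43%, the lowest of the three numbers and therefore the strongest effect in this set. The nearest is compound 3, whose value sits beyond the scatter above it; compound 2 lies furthest away, also beyond the scatter. Compound 3 also carries an acetyl group, on a different ring of the shared core, and its read-out is plainly weaker than that of compound 1.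

Compound 4 `COc1cc(C)cc(-c2c(-c3ccnc(-c4ccc(C(C)=O)cc4)c3)cnn2CC#N)c1` is not yet measured. Relative to compound 1 the change is acetyl in place of dimethylamino on an aromatic carbon. Going by the values given here, no measured pair in the set isolates this exact change, so the expectation rests on the weaker read-out of the other acetyl-bearing member, compound 3, which gives 11%. The step of a number 63 percentage points higher from compound 1 to compound 4 (beyond the scatter) is expected to run toward a higher number, beyond the scatter. Compound 4 is estimated at 20%, within -30% to 70%.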

Compound 4, a percentage reported as activity, at one concentration (the size of the read-out at that concentration, not a potency): 63%
Beside the measured number, compound 4's estimate is 43 percentage points below it; the range from low to high includes it.
By their numbers in this assay, from the lowest: compound 1; then compound 3; then compound 4; then compound 2.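

In this assay, acetyl in place of dimethylamino, on an aromatic carbon para to a large group, gives a number 106 percentage points higher from compound 1 to compound 4 (beyond the scatter). Going by these compounds alone, this is the first pair that differs in one place, and it shows that the read-out depends strongly on the group at this position, even though the two groups match in heavy-atom count and hydrogen-bond acceptor count and neither carries a net charge. Nothing measured here accounts for the size of this step.

Still open, from the compounds shown here alone, is whether the stronger effect of compound 1 is specific to dimethylamino or would also appear with another nitrogen group at this carbon, such as a primary amine, a diethylamino group or a morpholine. It is also unclear where a carboxylic acid or a methylsulfonyl group at this carbon would fall relative to this pair.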